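Truncation of the formamidine arm in compound 1

A few compounds are considered here, and "the series" means these few. Any claim that something is new, unique, unknown or untested is made for them only; others in the source may bear on it.

Compound 1 `CCOC(=O)C1=C(N/C=N/c2nnc(S(N)(=O)=O)s2)Nc2[nH]nc(C)c2C1c1ccc(N(C)C)cc1` carries a 5-sulfamoyl-1,3,4-thiadiazol-2-yl group on a double-bonded nitrogen of the formamidine chain and, in a functional assay on HeLa cells (Homo sapiens) for inhibition, read by MTT assay, with a stated time of 48 h (on this read-out higher numbers stand for weaker inhibition and lower numbers for stronger inhibition), compound 1 gives 26300 nM, the highest of the two numbers shown. Compound 2 `CCOC(=O)C1=C(N/C=N/c2cccnc2Cl)Nc2[nH]nc(C)c2C1c1ccc(N(C)C)cc1` gives 4630 nM, and the change of aryl group gives a 5.7-fold lower number from compound 1 to compound 2 (0.75 log units; beyond the scatter). Compound 3 `CCOC(=O)C1=C(N/N=C(/C(C)=O)C(=O)OCC)Nc2[nH]nc(C)c2C1c1ccc(N(C)C)cc1` sits at a limit of this assay, > 100000 nM, which is also (the limit of > 100000 nM in this assay, at which 1 of the 3 values shown sits). Replacing the whole arm on the amine nitrogen gives an at least 3.8-fold higher number from compound 1 to compound 3 (0.58 log units; beyond the scatter) and an at least 21-fold higher number from compound 2 to compound 3 (1.33 log units; beyond the scatter).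

Compound 4 `CCOC(=O)C1=C(N)Nc2[nH]nc(C)c2C1c1ccc(N(C)C)cc1` is not yet measured. Compared with compound 1, the change is a hydrogen atom in place of a group of 11 heavy atoms (3 carbon, 4 nitrogen, 2 oxygen, 2 sulfur; one five-membered aromatic ring with 3 hetero atoms), on an amine nitrogen. Going by the values given here, the step from compound 1 to compound 3 is the closest precedent, since it also removes the thiadiazole-bearing arm from the amine nitrogen and weakens inhibition beyond the scatter. A weakening step of at least modest size is therefore expected for compound 4, a 2.7-fold higher number from compound 1 to compound 4 (0.43 log units; beyond the scatter). Compound 4 is expected to give about 70000 nM, within 20000 nM to 250000 nM, possibly reported only as a limit.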

Compound 4, half-maximal inhibitory concentration: 6220 nM
Estimate against measurement, compound 4: 11-fold (1.05 log units) above; measured number below the stated range.
By their numbers in this assay, from the lowest: compounds 2 and 4 (each within the scatter of the next); then compound 1. At a limit, above all of these: compound 3.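

In this assay, hydrogen on the amine nitrogen does not cost inhibition: the thiadiazole-bearing arm comes off with a 4.2-fold lower number from compound 1 to compound 4 (0.63 log units; beyond the scatter), while the 2-chloropyridin-3-yl arm comes off with a 1.3-fold higher number from compound 2 to compound 4 (0.13 log units; within the scatter), so that arm shows no measurable gain over hydrogen. The arms on this nitrogen therefore do not act alike, and only the arm of compound 3 stands clearly on the weak side of the unsubstituted compound, with an at least 16-fold lower number from compound 3 to compound 4 (1.20 log units; beyond the scatter). The number for compound 3 is a limit and not a measured value: the limit of > 100000 nM in this assay, at which 1 of the 4 values shown sits.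

On these data alone, whether any group on this nitrogen can take the number clearly below that of compound 4 remains open, for instance a simple acetyl group or a longer alkyl chain. Also open, as far as these compounds go, is how compound 4 responds when the ethyl ester is replaced by a carboxylic acid.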